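A few compounds are considered here, and "the series" means these few. Any claim that something is new, unique, unknown or untested is made for them only; others in the source may bear on it.

Compound 1, with the structure `CCCOC(=O)Nc1ccc([Se]C#N)cc1`, is one of two compounds with a result in a functional assay on CCRF-CEM cells (Homo sapiens) for cytotoxicity, read by MTT assay, with a stated time of 72 h; a higher number here means a weaker inhibitor of growth, a lower number a stronger inhibitor of growth. In this assay compound 1 gives 9300 nM, the higher of the two numbers. The other measured compound is compound 2, built as `C=CCOC(=O)Nc1ccc([Se][Se]c2ccc(NC(=O)OCC=C)cc2)cc1`, and in this assay compound 2 gives 4600 nM, a lower number than compound 1 by a gap beyond the usual scatter; no single-point comparison between these two is drawn, because they differ in more than one place.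

The next compound is compound 3, with the structure `CCCCCCOC(=O)Nc1ccc([Se]C#N)cc1`. It differs from compound 1 by one change: propyl in place of hydrogen on a saturated chain carbon, three bonds along the chain from an oxygen next to a carbonyl group. For the measured compounds named here, no measured pair shows this kind of change, so the expectation rests on the shared core and on the value of compound 1 alone. For compound 3 a modest move toward a lower number is expected, a step of a 1.9-fold lower number from compound 1 to compound 3 (0.27 log units; within the scatter). Compound 3 is therefore estimated to give about 5000 nM in this assay, with a range from 1500 nM to 16000 nM.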

Compound 3, concentration for 50% growth inhibition: 19700 nM
For compound 3 the middle estimate is 3.9-fold (0.60 log units) below the measured one; measured number outside the range, above it.
By their numbers in this assay, from the lowest: compound 2; then compound 1; then compound 3.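

Here the change can be read on its own for the first time: propyl in place of hydrogen on a saturated chain carbon, three bonds along the chain from an oxygen next to a carbonyl group, gives a 2.1-fold higher number from compound 1 to compound 3 (0.33 log units; beyond the scatter) in this assay and so weakens growth inhibition. At this position, then, going from the propyl chain to the hexyl chain moves the number up by a modest step, not down. Nothing available here explains that direction.

A single step cannot show how the number changes with chain length in general, so a butyl chain or a longer chain such as octyl could fall anywhere relative to compound 3. The compounds shown also leave open what a chain ending in an amine or a carboxylic acid would do at this position.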